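Compound 3 to compound 4: a further methoxy

This account rests on a few compounds, and the source may have more. Where it says the series, first, only, none or still open, it means among the compounds named here.

Compounds measured in a functional assay on MCF7 cells (Homo sapiens) for inhibition, read by sulforhodamine B assay; on this read-out lower numbers stand for stronger inhibition of growth and higher numbers for weaker inhibition of growth:
- compound 1 `c1ccc(-c2ccc(-c3ccc(-c4nc5ccccc5[nH]4)cc3)cc2)cc1`: 39200 nM
- compound 2 `COc1ccc(-c2ccc(-c3ccc(-c4nc5cc(C)ccc5[nH]4)cc3)cc2)cc1OC`: 190 nM
- compound 3 `COc1ccc(-c2ccc(-c3ccc(-c4nc5ccccc5[nH]4)cc3)cc2)cc1`: 33300 nM

Not yet measured: compound 4 `COc1ccc(-c2ccc(-c3ccc(-c4nc5ccccc5[nH]4)cc3)cc2)cc1OC`.

Compound 3 gives 33300 nM and stands within the scatter of compound 1, at the high end of the three numbers. Compound 2 gives 190 nM, far lower than either. The change under consideration turns 4-methoxyphenyl into 3,4-dimethoxyphenyl: methoxy in place of hydrogen on an aromatic carbon. This is methoxy in place of hydrogen on an aromatic carbon, ortho to a methoxy group.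

Among the measured compounds shown here, only one measured step is of this kind: a 1.2-fold lower number from compound 1 to compound 3 (0.07 log units; within the scatter). Taken alone, it points to no shift beyond the scatter. Against that, compound 2 at 190 nM shows that much lower numbers occur in this small set, although no measured step links it to compound 3. Three compounds cannot settle the matter, so a move towards a lower number in this assay is expected, with its size poorly defined. The expected step is an 11-fold lower number from compound 3 to compound 4 (1.05 log units; beyond the scatter). The estimate for compound 4 is 3000 nM, with an expected range from 250 nM to 30000 nM.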

Compound 4, concentration for 50% growth inhibition: 7600 nM
For compound 4 the middle estimate is 2.5-fold (0.40 log units) below the measured one, within the range that was stated.
By their numbers in this assay, from the lowest: compound 2; then compound 4; then compounds 3 and 1 (each within the scatter of the next).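

In this assay, methoxy in place of hydrogen on an aromatic carbon now gives a step beyond the scatter when it stands ortho to a methoxy group, a 4.4-fold lower number from compound 3 to compound 4 (0.64 log units; beyond the scatter), whereas the earlier step of the same kind, a 1.2-fold lower number from compound 1 to compound 3 (0.07 log units; within the scatter), lay within it. Taken together, the change from phenyl to 3,4-dimethoxyphenyl gives a 5.2-fold lower number from compound 1 to compound 4 (0.71 log units; beyond the scatter), so this end of the molecule does affect the read-out once both methoxy groups are present. Among the compounds shown here, the new pair also ties compound 2 into the series: hydrogen in place of methyl on an aromatic carbon gives a 40-fold higher number from compound 2 to compound 4 (1.60 log units; beyond the scatter), the only step here rated large, which places most of the distance between compound 2 and compound 4 on that single methyl rather than on the methoxy change.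

Nothing available accounts for either step. As far as these compounds go, it remains open whether hydroxy or an amine in place of the second methoxy would give a step of similar size, and whether the same methyl would give a comparable step with phenyl or 4-methoxyphenyl at the far end.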